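From methoxy to phenyl at the assay limit

The source may report more compounds than this note shows. Statements on the series, on what has been measured and on what is new or still open speak of the compounds shown alone.

Measured in an ADME assay on WI-38 cells (Homo sapiens) for cytotoxicity, read by MTT assay, with a stated time of 72 h; a lower number here means a stronger inhibitor, a higher number a weaker inhibitor:
Compound 1 `Cc1ccc(NC(=O)CCc2cccc3c2B(O)OC3)cc1` gives > 100000 nM (a limit)
Compound 2 `COc1ccc(NC(=O)CCc2cccc3c2B(O)OC3)cc1` gives > 100000 nM (a limit)

Compound 2 stands at > 100000 nM in this assay and this is a limit of the assay, not a number. The two measured compounds have this in common: the limit of > 100000 nM in this assay, at which 2 of the 2 values shown sit. Compound 3 `O=C(CCc1cccc2c1B(O)OC2)Nc1ccc(-c2ccccc2)cc1` is still unmeasured. It has phenyl in place of methoxy on an aromatic carbon, para to a large group, and the counted change is phenyl in place of methoxy on an aromatic carbon.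

Going by the values given here, the one measured step that bears on this is a step that the two limits leave unreadable from compound 1 to compound 2 and it offers no size to carry over. Among the compounds with values here, no measured step involves phenyl. Within the data shown here, no step of a definite size is therefore expected in this assay. Resting on the limit of compound 2 at > 100000 nM the expectation is that compound 3 will most likely return a limit as well, and that any number it does give will lie lower. The expected step is a number no higher from compound 2 to compound 3 (the limit leaves the size open) and it stays uncertain. Compound 3 is estimated at 100000 nM with an expected range from 30000 nM to 200000 nM in this reading.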

Compound 3, half-maximal inhibitory concentration: 32000 nM
Compound 3: middle estimate off by 3.1-fold (0.49 log units), on the high side; measured number inside the range.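

Until now, this position had given no number: in this assay, compound 1 and compound 2 both rest at a limit of the assay, not a measured value: the limit of > 100000 nM in this assay, at which 2 of the 3 values shown sit.

On an aromatic carbon, para to a large group, phenyl is the first group shown to give a number, with compound 3 at 32000 nM in this assay. Phenyl in place of methoxy gives an at least 3.1-fold lower number from compound 2 to compound 3 (0.49 log units; beyond the scatter), and phenyl in place of methyl gives an at least 3.1-fold lower number from compound 1 to compound 3 (0.49 log units; beyond the scatter), so the position can respond to a change of group, although the true size of both steps stays open.

The compounds shown leave open whether another group at this place, such as an amine, a carboxylic acid or a benzyl group, would also give a number in this assay. Going by these compounds alone, with phenyl as the only group of its kind here, they also cannot separate the presence of the six-membered aromatic ring from the larger count of heavy atoms that enters with it.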